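This account rests on a few compounds, and the source may have more. Where it says the series, first, only, none or still open, it means among the compounds named here.

Working notes on the series. a functional assay on B16-F10 cells (Mus musculus) for antiproliferative activity, read by MTT assay, with a stated time of 48 h (on this read-out higher numbers stand for weaker inhibition and lower numbers for stronger inhibition), covers three measured compounds. Compound 1 `Cc1ncc([N+](=O)[O-])n1CC(=O)NS(=O)(=O)c1ccc(Br)cc1` gives 2.37 ug/mL, the lowest of the three numbers, with steps to both others beyond the scatter. Compound 2 `Cc1ccc(S(=O)(=O)NC(=O)Cc2ccc(F)cc2)cc1` gives 9.94 ug/mL, and compound 3 `O=C(Cc1ccc(F)cc1)NS(=O)(=O)c1ccccc1` gives 9.07 ug/mL; the step of a 1.1-fold lower number from compound 2 to compound 3 (0.04 log units; within the scatter) is within the scatter, so the methyl on the aromatic carbon of the sulfonyl-bearing ring is not seen to matter between these two.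

Compound 4 `Cc1ccc(S(=O)(=O)NC(=O)Cn2c([N+](=O)[O-])cnc2C)cc1` is not yet measured. It differs from compound 1 as follows: methyl in place of bromo on an aromatic carbon. Going by the values given here, no measured pair differs by bromo against methyl, so the only guide is the indifference of this position to methyl against hydrogen in the step from compound 2 to compound 3, which was within the scatter. The expected change is therefore small, with at most a modest rise in number from compound 1, and the estimate for this assay is a step of a 1.4-fold higher number from compound 1 to compound 4 (0.13 log units; within the scatter).

The estimate for compound 4 in this assay is 3.2 ug/mL, with a range from 1.5 ug/mL to 7 ug/mL.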

Compound 4, half-maximal inhibitory concentration: 3.55 ug/mL
Compound 4: middle estimate off by 1.1-fold (0.05 log units), on the low side; the range from low to high includes it.
By their numbers in this assay, from the lowest: compounds 1 and 4 (each within the scatter of the next); then compounds 3 and 2 (each within the scatter of the next).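

In this assay, going by these compounds alone, the step of a 1.5-fold higher number from compound 1 to compound 4 (0.18 log units; within the scatter) gives the first direct reading of bromo against methyl on this aromatic carbon, para to a large group. The change from 4-bromophenyl to 4-methylphenyl does not separate the two compounds, and the earlier methyl-to-hydrogen step, a 1.1-fold lower number from compound 2 to compound 3 (0.04 log units; within the scatter), also stays within the scatter on a different shared core, so two separate exchanges at this position now show no readable change. No measured evidence bears on this result.

Open, as far as these compounds go, is whether the position stays as indifferent with a group of another kind, such as an amine, a carboxylic acid or a longer chain. Also open, from the compounds shown here alone, is whether hydrogen in this place would read the same on the core of compound 1.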